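Benzyl in Place of 4-Chlorophenyl on the Amine Nitrogen

A few compounds are considered here, and "the series" means these few. Any claim that something is new, unique, unknown or untested is made for them only; others in the source may bear on it.

In a functional assay on A549 cells (Homo sapiens) for cytotoxicity, read by MTT assay, with a stated time of 48 h (a higher number here means a weaker inhibitor, a lower number a stronger inhibitor), compound 1 `Cc1ccc(S(=O)(=O)/N=C(/CCNC2=CC(=O)c3ccccc3C2=O)Nc2ccc(Cl)cc2)cc1` gives 29900 nM, the second highest of three numbers. Compound 2 `Cc1ccc(S(=O)(=O)/N=C(/CCNC2=CC(=O)c3ccccc3C2=O)Nc2cccc(C)c2)cc1` gives 18700 nM and compound 3 `Cc1ccc(S(=O)(=O)/N=C(/CCNC2=CC(=O)c3ccccc3C2=O)NC(C)C)cc1` gives 44300 nM. The step of a 1.6-fold lower number from compound 1 to compound 2 (0.20 log units; within the scatter) and the step of a 1.5-fold higher number from compound 1 to compound 3 (0.17 log units; within the scatter) both stay within the scatter, while a 2.4-fold higher number from compound 2 to compound 3 (0.37 log units; beyond the scatter) is modest. Compound 4 `Cc1ccc(S(=O)(=O)/N=C(/CCNC2=CC(=O)c3ccccc3C2=O)NCc2ccccc2)cc1` differs from compound 1 by benzyl in place of 4-chlorophenyl on an amine nitrogen. The change leaves one aromatic ring for another with the same heavy-atom count, as in the steps from compound 1 to compounds 2 and 3, which moved the number little either way. Compound 4 is therefore expected to show no step beyond the scatter, a 1.0-fold higher number from compound 1 to compound 4 (0.00 log units; within the scatter), and its estimated value in this assay is 30000 nM, between 12000 nM and 75000 nM.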

Compound 4, half-maximal inhibitory concentration: 7410 nM
Compound 4: the middle estimate sits 4.0-fold (0.61 log units) above what was measured; measured number below the stated range.
By their numbers in this assay, from the lowest: compound 4; then compounds 2, 1 and 3 (each within the scatter of the next, the first and the last beyond it).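

In this assay, benzyl on this amine nitrogen stands apart from all three other groups: the steps (a 4.0-fold lower number from compound 1 to compound 4 (0.61 log units; beyond the scatter)), (a 2.5-fold lower number from compound 2 to compound 4 (0.40 log units; beyond the scatter)) and (a 6.0-fold lower number from compound 3 to compound 4 (0.78 log units; beyond the scatter)) all lie beyond the scatter, making compound 4 the strongest of the four. Going by these compounds alone, the change from (4-chlorophenyl)amino to benzylamino keeps the heavy-atom count and the aromatic ring, yet the number still moves, so this position is more sensitive than the earlier compounds suggested. Nothing here gives a measured reason for this. As far as these compounds go, whether a phenethyl chain or a 4-chlorobenzyl group would keep the lower number stays open.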